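A few compounds are considered here, and "the series" means these few. Any claim that something is new, unique, unknown or untested is made for them only; others in the source may bear on it.

Four close relatives of one shared core were compared in a functional assay on MCF7 cells (Homo sapiens) for inhibition, read by sulforhodamine B assay; a higher number here means a weaker inhibitor, a lower number a stronger inhibitor. Compound 1 `O=C1C=C(Nc2ccc(I)cc2)C(=O)c2c1nc1n2[C@H]2OC[C@@H](O)[C@H]2OC1` gives 2230 nM. Compound 3 `O=C1C=C(NC2CCCC2)C(=O)c2c1nc1n2[C@H]2OC[C@@H](O)[C@H]2OC1` is reported only as a limit, > 16000 nM. Among the compounds with values here, the change between them, an at least 7.1-fold higher number from compound 1 to compound 3 (0.85 log units; beyond the scatter), is the only measured step here. From the compounds shown here alone, compound 2 `O=C1C(N2CCCCC2)=CC(=O)c2c1nc1n2[C@H]2OC[C@@H](O)[C@H]2OC1` likewise sits only at a limit, > 8000 nM, so where it truly stands past that boundary is unknown. Compound 4 `O=C1C(N2CCCC2)=CC(=O)c2c1nc1n2[C@H]2OC[C@@H](O)[C@H]2OC1` differs from compound 2 by pyrrolidin-1-yl in place of piperidin-1-yl on a double-bonded ring carbon. Within the data shown here, no measured step swaps one such cyclic amine for another, and the one step available changes a different kind of group. No step beyond the scatter is expected for compound 4, whose value is estimated at 12000 nM, between 4000 nM and 40000 nM, that is a step that the limit leaves unreadable from compound 2 to compound 4, most likely reported again only as a limit.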

Compound 4, half-maximal inhibitory concentration: > 16000 nM
Compound 4: a limit, no number; the forecaster's own chance of this, stated with the estimate: 70%; at least 1.3-fold (0.12 log units) between middle value and limit.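

Compound 2 and compound 4 are both reported only as limits, and the step between them cannot be read. From the compounds shown here alone, whether pyrrolidin-1-yl in place of piperidin-1-yl changes inhibition at all remains open.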